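Hydroxamic-free benzamide series: linker change at compound 4

A few compounds are considered here, and "the series" means these few. Any claim that something is new, unique, unknown or untested is made for them only; others in the source may bear on it.

Measured so far:
compound 1 `Nc1ccccc1NC(=O)c1ccc(Cn2cnc3c(Nc4ccc(-c5ccccn5)cc4)nc(Cl)nc32)cc1` — 73.7%
compound 2 `Nc1ccccc1NC(=O)c1ccc(Cn2cnc3c(Nc4cccc(OC(F)(F)F)c4)nc(Cl)nc32)cc1` — 46.6%
compound 3 `Cc1ccc(Nc2nc(Cl)nc3c2ncn3Cc2ccc(/C=C/C(=O)Nc3ccccc3N)cc2)cc1` — 15%

In a functional assay on HCT-116 cells (Homo sapiens) for antiproliferative activity, read by CCK-8 assay, with a stated time of 72 h, tested at 8 uM (a higher number here means a stronger effect of the compound at the concentration tested, a lower number a weaker effect), compound 1 gives 73.7%, compound 2 gives 46.6% and compound 3 gives 15%. Compound 3 stands lowest of the three, with compound 2 nearest and compound 1 furthest, both beyond the scatter. Among the compounds with values here, the one step between measured compounds that differ in a single place is a number 27.1 percentage points lower from compound 1 to compound 2 (beyond the scatter), and it concerns the group on the nitrogen on the aromatic ring, not the part changed here.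

Compound 4 `Cc1ccc(Nc2nc(Cl)nc3c2ncn3Cc2ccc(C(=O)Nc3ccccc3N)cc2)cc1` has not yet been measured. It differs from compound 3 in this way: (2-aminophenyl)carbamoyl in place of 2-((2-aminophenyl)carbamoyl)ethenyl on an aromatic carbon. Within the data shown here, no measured step covers this change directly; what can be said is that compound 1 and compound 2, which carry the (2-aminophenyl)carbamoyl group on the same ring as compound 4, both give higher numbers than compound 3, though their cores differ from compound 4 elsewhere. On that basis a rise is expected for compound 4, of about a number 25 percentage points higher from compound 3 to compound 4 (beyond the scatter), with wide uncertainty. Compound 4 is estimated at 40%, within 15% to 70%.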

Compound 4, a percentage reported as inhibition, at one concentration (the size of the read-out at that concentration, not a potency): 81.5%
The estimate for compound 4 lay 41.5 percentage points below the measured number; the whole stated range lies below it.
By their numbers in this assay, from the lowest: compound 3; then compound 2; then compounds 1 and 4 (each within the scatter of the next).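

In this assay, within the data shown here, (2-aminophenyl)carbamoyl in place of 2-((2-aminophenyl)carbamoyl)ethenyl, on the aromatic carbon para to a large group, gives a number 66.5 percentage points higher from compound 3 to compound 4 (beyond the scatter) and provides the first direct reading of this change. With the (2-aminophenyl)carbamoyl group held constant, 4-methylphenyl in place of 3-(trifluoromethoxy)phenyl gives a number 34.9 percentage points higher from compound 2 to compound 4 (beyond the scatter) and methyl in place of pyridin-2-yl gives a number 7.8 percentage points higher from compound 1 to compound 4 (within the scatter) so the pyridin-2-yl group is not required for a read-out of this size among these compounds. No available evidence accounts for the size of the linker step.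

Among these compounds, whether the linker step holds with the other groups on the nitrogen remains open, as the ethenyl linker is seen only with 4-methylphenyl. Also open, from the compounds shown here alone, is how a saturated ethyl linker or a longer chain would read at this position, and whether an amine in place of the chlorine on the core would keep the read-out.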